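Methoxy in place of propyl on the piperidine ring

The source may report more compounds than this note shows. Statements on the series, on what has been measured and on what is new or still open speak of the compounds shown alone.

Two members of the series carry measurements. Compound 1 `COc1ccc(COc2cc(N)c(Cl)cc2C(=O)CCCCN2CCCCC2)cc1OC` and compound 2 `CCCC1CCN(CCCCC(=O)c2cc(Cl)c(N)cc2OCc2cc(OC)cc(OC)c2)CC1` share the same chain and aryl part and differ at the piperidine substituent and in the arrangement of the methoxy groups on the benzyl ring. In a functional assay for antagonist activity at 5-hydroxytryptamine receptor 4 (Rattus norvegicus) (a lower number here means a less potent compound, a higher number a more potent compound, by a factor of ten per unit of this negative logarithm), compound 1 gives 8.5, and compound 2 gives 7.7. Compound 2 therefore stands lowest of the two numbers, with the value of compound 1 lying higher by a margin beyond the scatter.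

Compound 3 `COc1cc(COc2cc(N)c(Cl)cc2C(=O)CCCCN2CCC(OC)CC2)cc(OC)c1` remains to be measured. It departs from compound 2 by methoxy in place of propyl on a saturated ring carbon. Among the compounds with values here, no measured pair differs only at this place, so the size of this step cannot be read from the data; the expectation is a step near zero in either direction, not beyond the scatter. For compound 3 the expected value in this assay is 7.8, within a range from 7.1 to 8.5. The implied step a number 0.10 log units higher from compound 2 to compound 3 (within the scatter) is expected to stay within the scatter.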

Compound 3, negative logarithm of the antagonist equilibrium constant: 8.4
For compound 3 the middle estimate is 0.60 log units below the measured one; the measured number falls inside the stated range.
By their numbers in this assay, from the lowest: compound 2; then compounds 3 and 1 (each within the scatter of the next).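

Methoxy in place of propyl on a saturated ring carbon gives a number 0.70 log units higher from compound 2 to compound 3 (beyond the scatter) in this assay and is a single change, so this position alone can move the number by more than the scatter, which compounds 1 and 2, differing in two places, could not show. The swap of 4-propylpiperidin-1-yl for 4-methoxypiperidin-1-yl removes a three-carbon chain and adds one oxygen and one hydrogen-bond acceptor, and the pair cannot separate the contributions of these differences. No measurement available here explains the step.

Open, going by these compounds, is whether a hydroxyl, an amine or a longer ether such as ethoxy at this ring carbon would follow methoxy or propyl. Within the data shown here, the effect of the methoxy arrangement on the benzyl ring also stays unread, as no pair differs only there.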